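This account rests on a few compounds, and the source may have more. Where it says the series, first, only, none or still open, it means among the compounds named here.

Measured so far:
compound 1, `Cc1ccc2oc(SCC(=O)Nc3ccc(-c4nc(-c5ccccc5)c(-c5ccccc5)n4C)cc3)nc2c1`, 1.9%
compound 2, `Cn1nnnc1SCC(=O)Nc1ccc(-c2nc(-c3ccccc3)c(-c3ccccc3)n2C)cc1`, 34.3%

Among the measured compounds shown here, in a functional assay on MCF7 cells (Homo sapiens) for cytotoxicity, read by MTT assay, with a stated time of 24 h, tested at 1.6 ug/mL (on this read-out higher numbers stand for a stronger effect at the one concentration tested and lower numbers for a weaker effect), compound 2 stands at the higher of the two numbers known; its nearest neighbour is compound 1, reached through the step of a number 32.4 percentage points higher from compound 1 to compound 2 (beyond the scatter). Compound 3, `CCN1CCN(CC(=O)Nc2ccc(-c3nc(-c4ccccc4)c(-c4ccccc4)n3C)cc2)CC1`, is still to be measured in this assay. It differs from compound 2 in one place: 4-ethylpiperazin-1-yl in place of (1-methyl-1H-tetrazol-5-yl)sulfanyl on a saturated chain carbon bound to a carbonyl carbon. For the measured compounds named here, no measured step covers this exchange. Going by the values given here, the only step known, a number 32.4 percentage points higher from compound 1 to compound 2 (beyond the scatter), shows that swapping the group sitting on the sulfur changed the read-out by a large amount, so the part of the molecule on a saturated chain carbon bound to a carbonyl carbon clearly matters here. With the sulfur itself now removed and a saturated ring put in its place, a sizeable shift in either direction seems possible. Compound 3 is estimated at 20%, with a range from 2% to 50%. This estimate means an expected step of a number 14.3 percentage points lower from compound 2 to compound 3 (beyond the scatter).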

Compound 3, a percentage reported as activity, at one concentration (the size of the read-out at that concentration, not a potency): 14.6%
Beside the measured number, compound 3's estimate is 5.4 percentage points above it, and the stated range covers the measured number.
By their numbers in this assay, from the lowest: compound 1; then compound 3; then compound 2.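

Replacing the sulfur-linked group on a saturated chain carbon bound to a carbonyl carbon with 4-ethylpiperazin-1-yl, a non-aromatic ring attached without sulfur, still leaves a clear reading in this assay. The change gives a number 19.7 percentage points lower from compound 2 to compound 3 (beyond the scatter), yet it also gives a number 12.7 percentage points higher from compound 1 to compound 3 (beyond the scatter), so among these compounds a sulfanyl link is neither required for a reading nor a guarantee of a high one: the new group places compound 3 between the two sulfur-linked compounds. No available evidence explains this order.

Going by these compounds, it remains open whether morpholin-4-yl or a simple diethylamino group at this place would read nearer compound 1 or compound 2. On these data alone, it is also open whether the 1-methyl-1H-tetrazol-5-yl ring would keep the reading of compound 2 if attached without its sulfur.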